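Sulfone replacing thioether in a kinase series

The source may hold more compounds than are shown below. What is called first, only, known or untested is meant among the compounds shown, and "the series" means these compounds.

The series is read in an assay on isolated protein for inhibition of Rho-associated protein kinase 1 (Homo sapiens), tested at 30 uM; on this read-out higher numbers stand for more inhibition at the one concentration tested (going by the name of the read-out) and lower numbers for less inhibition. Compound 1 `Cn1cnc2c(Sc3ccc(F)cc3)ncnc21` gives 6% in this assay. Compound 2 `CSc1ccc(-c2nc3c(Sc4ccc(F)cc4)ncnc3n2C)cc1` carries 4-(methylsulfanyl)phenyl in place of hydrogen on an aromatic carbon; in this assay compound 2 gives 0%. The step of a number 6 percentage points lower from compound 1 to compound 2 (within the scatter) lies within the scatter, so the two numbers cannot be told apart, and both sit close to zero. Compound 2 thus stands among two indistinguishable numbers, both close to zero.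

Compound 3 `Cn1c(-c2ccc(S(C)(=O)=O)cc2)nc2c(Sc3ccc(F)cc3)ncnc21` differs from compound 2 by methylsulfonyl in place of methylsulfanyl on an aromatic carbon. For the measured compounds named here, the only measured step, a number 6 percentage points lower from compound 1 to compound 2 (within the scatter), concerns a different place and was itself within the scatter; no measured step covers methylsulfonyl for methylsulfanyl. With both measured numbers near zero and no step beyond the scatter anywhere in the data, no change beyond the scatter is expected in this assay for compound 3, the expected step being a number 3 percentage points higher from compound 2 to compound 3 (within the scatter). Compound 3 is therefore estimated to give 3% in this assay, with a range from -8% to 15%.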

Compound 3, a percentage reported as inhibition, at one concentration (the size of the read-out at that concentration, not a potency): 0%
The estimate for compound 3 lay 3 percentage points above the measured number; measured number inside the range.
By their numbers in this assay, from the lowest: compounds 2, 3 and 1 (each within the scatter of the next).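

Methylsulfonyl in place of methylsulfanyl on this ring gives no change at the digits printed from compound 2 to compound 3 (within the scatter) in this assay, so this position has now been varied directly and the read-out registers no inhibition from either group. For the compounds shown here, with both numbers at the bottom of the read-out at the one concentration tested, the step cannot show that the two groups are equivalent; it shows only that this change does not lift the compound clear of the scatter. Nothing available here bears on why the number stays where it stands.

Still open, from the compounds shown here alone, is whether an amine or a carboxylic acid in place of methylsulfonyl on this ring would bring inhibition clearly beyond the scatter, or whether this position stays silent whatever it carries. Also open, going by these compounds, is whether a change elsewhere on the shared core, such as a longer chain in place of its methyl, would give a measurable number against which changes at this position could be properly compared.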